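This account rests on a few compounds, and the source may have more. Where it says the series, first, only, none or still open, it means among the compounds named here.

Measured so far:
Compound 1 `COc1ccc(NC(=O)CN2CCN(S(=O)(=O)N3CCC(C)CC3)CC2)cc1` — > 10000 nM
Compound 2 `COc1ccc(Cl)cc1NC(=O)CN1CCN(S(=O)(=O)N2CCN(C(=O)N3CCCCCC3)CC2)CC1` — > 10000 nM

The piece follows the step from compound 1 to compound 3. In an assay on HEK293 cells for activation of potassium channel subfamily T member 1 (Homo sapiens), read by thallium flux (on this read-out lower numbers stand for an effect already at smaller amounts and higher numbers for an effect only at larger amounts of compound), compound 1 gives > 10000 nM; this is a limit of the assay, not a measured number. Compound 2 in this assay gives > 10000 nM, again a limit rather than a number. So compound 1 stands nowhere in particular on a scale: both values shown sit at the limit of > 10000 nM in this assay, at which 2 of the 2 values shown sit, and no step between measured compounds can be given a size.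

Compound 3 `CC1CCN(S(=O)(=O)N2CCN(CC(=O)Nc3cccc(F)c3)CC2)CC1` differs from compound 1 in one place: 3-fluorophenyl in place of 4-methoxyphenyl on an amide-type nitrogen. The rest of the shared core is kept. With nothing in the data that separates any two compounds, no direction for this change can be read off. The expectation is a step from compound 1 to compound 3 of a number no higher from compound 1 to compound 3 (the limit leaves the size open), that is, none beyond the scatter. Compound 3 is therefore estimated at 10000 nM, with a range from 3000 nM to 30000 nM, and most likely the assay will again report only a limit.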

Compound 3, half-maximal effective concentration: 4600 nM
For compound 3 the middle estimate is 2.2-fold (0.34 log units) above the measured one; low and high end bracket the measured number.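

In this assay, putting 3-fluorophenyl in place of 4-methoxyphenyl on the amide-type nitrogen gives an at least 2.1-fold lower number from compound 1 to compound 3 (0.33 log units; beyond the scatter), so the read-out does respond to a change at this place while the rest of the shared core stays the same. Going by these compounds alone, compound 3, at 4600 nM, is also the first compound here with an actual number rather than a limit, which gives any further change to compound 3 a firm value to be compared against. The step itself can only be given as a minimum size, because its starting point is a limit and not a number: the limit of > 10000 nM in this assay, at which 2 of the 3 values shown sit.

Nothing shown separates the effect of losing 4-methoxyphenyl from the effect of gaining 3-fluorophenyl, and how a plain phenyl or a pyridyl ring on the same nitrogen would read remains open. Compound 2 differs from compound 1 in more than one place, so it cannot show what any single part of the molecule contributes, and whether the other end of the shared core, with its 4-methylpiperidine, matters is also unknown.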